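Swapping the Heteroaryl on a Sulfonamide Nitrogen

The source may hold more compounds than are shown below. What is called first, only, known or untested is meant among the compounds shown, and "the series" means these compounds.

Compound 1 `C=C1CC[C@@H]2[C@](C)(COC(C)=O)[C@H](OC(C)=O)CC[C@@]2(C)[C@H]1CC(Nc1ccc(S(=O)(=O)Nc2ccc(Cl)nn2)cc1)C1=CCOC1=O` was tested in a functional assay on SN12C cells (Homo sapiens) for inhibition, read by sulforhodamine B assay, with a stated time of 48 h (a lower number here means a stronger inhibitor of growth, a higher number a weaker inhibitor of growth), where compound 1 gives 3660 nM. Among the three numbers measured so far it stands second highest: the nearest is compound 2 `C=C1CC[C@@H]2[C@](C)(COC(C)=O)[C@H](OC(C)=O)CC[C@@]2(C)[C@H]1CC(Nc1ccc(S(=O)(=O)Nc2cc(C)on2)cc1)C1=CCOC1=O` at 4520 nM, and the furthest is compound 3 `C=C1CC[C@@H]2[C@](C)(COC(C)=O)[C@H](OC(C)=O)CC[C@@]2(C)[C@H]1CC(Nc1ccc(S(=O)(=O)Nc2ncccn2)cc1)C1=CCOC1=O` at 1960 nM.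

Compound 4 `C=C1CC[C@@H]2[C@](C)(COC(C)=O)[C@H](OC(C)=O)CC[C@@]2(C)[C@H]1CC(Nc1ccc(S(=O)(=O)Nc2nccs2)cc1)C1=CCOC1=O` differs from compound 1 in one place: 1,3-thiazol-2-yl in place of 6-chloropyridazin-3-yl on a sulfonamide nitrogen. Among the compounds with values here, three measured steps bear on this kind of swap, since all three measured compounds differ only in the group on the sulfonamide nitrogen. From compound 1 the steps are a 1.2-fold higher number from compound 1 to compound 2 (0.09 log units; within the scatter) and a 1.9-fold lower number from compound 1 to compound 3 (0.27 log units; within the scatter), both within the scatter, while between the other two the step is a 2.3-fold lower number from compound 2 to compound 3 (0.36 log units; beyond the scatter), a modest one. Exchanging this group has therefore moved the number only a little in either direction, and for compound 4 a step of a 1.2-fold lower number from compound 1 to compound 4 (0.09 log units; within the scatter) is expected, not beyond the scatter. Compound 4 is accordingly estimated at 3000 nM, with a range from 1500 nM to 6500 nM.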

Compound 4, concentration for total growth inhibition: 4390 nM
For compound 4 the middle estimate is 1.5-fold (0.17 log units) below the measured one; low and high end bracket the measured number.
By their numbers in this assay, from the lowest: compounds 3, 1, 4 and 2 (each within the scatter of the next, the first and the last beyond it).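

Replacing the six-membered 6-chloropyridazin-3-yl with the smaller, five-membered 1,3-thiazol-2-yl gives a 1.2-fold higher number from compound 1 to compound 4 (0.08 log units; within the scatter) in this assay so neither the change of ring size nor the loss of chlorine separates these two compounds. The other five-membered ring, 5-methyl-1,2-oxazol-3-yl, tells the same story, with a 1.0-fold lower number from compound 2 to compound 4 (0.01 log units; within the scatter) and no separation from the thiazole. Only pyrimidin-2-yl stands somewhat apart, with a 2.2-fold higher number from compound 3 to compound 4 (0.35 log units; beyond the scatter) as a modest step, which places both five-membered rings beyond the scatter from it, while the 6-chloropyridazin-3-yl of compound 1 remains within the scatter of it.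

Still open, from the compounds shown here alone, is whether this tolerance extends to a plain phenyl ring, a simple methyl group or a chain ending in a carboxylic acid on the sulfonamide nitrogen. No measurement shown here explains why pyrimidin-2-yl stands apart.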